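A few compounds are considered here, and "the series" means these few. Any claim that something is new, unique, unknown or untested is made for them only; others in the source may bear on it.

Two members of the series have numbers in a functional assay on cells (Lymphocyte, Homo sapiens); on this read-out lower numbers stand for stronger inhibition and higher numbers for weaker inhibition. Compound 1 `Cc1cccc(NC(=O)N2CCN(c3nc(N)nc4sc(-c5ccc(F)cc5)nc34)CC2)c1` gives 300 nM. Compound 2 `Nc1nc(N2CCN(C(=O)COc3ccc(Cl)cc3)CC2)c2nc(Cc3ccc(F)cc3)sc2n1` gives 700 nM, the higher of the two numbers, beyond the scatter relative to compound 1. Compound 3 `Nc1nc(N2CCN(C(=O)COc3ccc(Cl)cc3)CC2)c2nc(-c3ccccn3)sc2n1` carries the change (pyridin-2-yl in place of 4-fluorobenzyl on an aromatic carbon). Within the data shown here, no pair of measured compounds isolates this change, so its size is not known from the data; compound 1, which also carries a ring attached directly to that aromatic carbon, gives 300 nM, and a modest step down is expected, a 1.8-fold lower number from compound 2 to compound 3 (0.24 log units; within the scatter). Compound 3 is estimated at 400 nM, with a range from 150 nM to 1200 nM.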

Compound 3, half-maximal inhibitory concentration: 230 nM
Estimate against measurement, compound 3: 1.7-fold (0.24 log units) above; the range from low to high includes it.
By their numbers in this assay, from the lowest: compounds 3 and 1 (each within the scatter of the next); then compound 2.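

In this assay, pyridin-2-yl in place of 4-fluorobenzyl gives a 3.0-fold lower number from compound 2 to compound 3 (0.48 log units; beyond the scatter) with the rest of the structure unchanged, the first clean read at this position. The aromatic carbon next to the ring nitrogen and the ring sulfur therefore does not depend on 4-fluorobenzyl for activity and tolerates a directly attached ring bearing a hetero atom. No measured property bears on this step. Going by these compounds, whether the step follows the ring nitrogen or the direct attachment stays open. Phenyl or pyridin-3-yl at this position, with the rest of compound 3 unchanged, would separate the two.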